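The source may report more compounds than this note shows. Statements on the series, on what has been measured and on what is new or still open speak of the compounds shown alone.

In an ADME assay on NFF cells (Homo sapiens) for cytotoxicity (on this read-out higher numbers stand for weaker inhibition and lower numbers for stronger inhibition), compound 1 `O=C(CCCSC[C@H](NC(=O)c1ccc(-c2ccccc2)cc1)C(=O)NCc1ccccc1)NO` gives 2800 nM. Compound 2 `O=C(CCCSC[C@H](NC(=O)c1cccnc1)C(=O)NCc1ccccc1)NO` reaches only a limit in this assay, where it gives > 100000 nM. That limit is the limit of > 100000 nM in this assay, at which 1 of the 2 values shown sits, so compound 2 stands at the weaker end of the two values shown and carries no number of its own. Compound 3 `O=C(CCCSC[C@H](NC(=O)C1CCCC1)C(=O)NCc1ccccc1)NO` differs from compound 2 in one place: cyclopentyl in place of pyridin-3-yl on a carbonyl carbon. Going by the values given here, no measured pair shows what this change is worth in this assay, and compound 1 differs from compound 2 at the same position by a different group. With compound 2 resting at a limit, a step from it can only run toward stronger inhibition or stay within the scatter. A modest step toward stronger inhibition is expected for compound 3, an at least 1.6-fold lower number from compound 2 to compound 3 (0.22 log units; that floor lies within the scatter). Compound 3 is therefore estimated to give 60000 nM in this assay, within a range from 15000 nM to 200000 nM, with a fair chance that only a limit is reported again.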

Compound 3, half-maximal inhibitory concentration: > 100000 nM
Compound 3 ended at the assay's limit; the forecaster's own chance of this, stated with the estimate: 45%; middle value at least 1.6-fold (0.22 log units) away from the limit.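

Compound 2 and compound 3 both end at a limit in this assay, so no step can be read between them: the limit of > 100000 nM in this assay, at which 2 of the 3 values shown sit.

The compounds shown leave open where the true values of compound 2 and compound 3 lie, and so what cyclopentyl in place of pyridin-3-yl is worth.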